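The compounds below may be only part of what the source reports. "The series", "measured", "known", "first", "only" and "open" are said of these compounds alone.

Measured so far in a functional assay on L1210 cells (Mus musculus) for cytotoxicity, with a stated time of 4 days; a lower number here means that less compound is needed, a higher number that more compound is needed for the effect:
- compound 1 (`CC1=CC(=O)CC(C)(C)[C@@]1(O)CC(=O)/C(C)=C/C=C/C(C)=C/C=C/C=C(C)/C=C/C=C(\C)C=C=C1C(C)(C)C[C@H](O)C[C@@]1(C)O`) gives 50 ug/mL
- compound 2 (`CC1=C(C#C/C(C)=C/C=C/C(C)=C/C=C/C=C(C)/C=C/C=C(\C)C(=O)C[C@@]23O[C@]2(C)C[C@@H](O)CC3(C)C)C(C)(C)C[C@H](O)C1`) gives 25 ug/mL

On these two numbers, compound 2 stands level with compound 1 within the scatter, and no trend can be read from the pair. The next compound to be measured is compound 3 (`CC1=CC(=O)CC(C)(C)[C@@]1(O)CC(=O)/C(C)=C/C=C/C(C)=C/C=C/C=C(C)/C=C/C=C(\C)C#CC1=C(C)C[C@@H](O)CC1(C)C`). The change from compound 2 to compound 3, on a saturated chain carbon bound to a carbonyl carbon, brings in 1-hydroxy-2,6,6-trimethyl-4-oxocyclohex-2-en-1-yl (a group of 11 heavy atoms (9 carbon, 2 oxygen; one six-membered non-aromatic ring of carbon only) in place of a group of 11 heavy atoms (9 carbon, 2 oxygen; one three-membered non-aromatic ring with 1 hetero atom, one six-membered non-aromatic ring of carbon only), on a saturated chain carbon bound to a carbonyl carbon), a group that compound 1 also carries. The rest of compound 3 matches compound 2. Within the data shown here, no measured pair isolates this change, so any expectation is loose. Compound 1, with this group, gives 50 ug/mL and compound 2, without it, gives 25 ug/mL in this assay, so no step beyond the scatter is expected, with a slight lean towards a higher number. The expected step is a 1.4-fold higher number from compound 2 to compound 3 (0.15 log units; within the scatter) and it should stay within the scatter. For compound 3 the estimated value is 35 ug/mL with an expected range from 15 ug/mL to 80 ug/mL in this assay once measured.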

Compound 3, concentration for half-maximal effect: 100 ug/mL
Compound 3: middle estimate off by 2.9-fold (0.46 log units), on the low side; measured number outside the range, above it.
By their numbers in this assay, from the lowest: compounds 2, 1 and 3 (each within the scatter of the next, the first and the last beyond it).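

In this assay, putting 1-hydroxy-2,6,6-trimethyl-4-oxocyclohex-2-en-1-yl in place of the group with the three-membered ring, on a saturated chain carbon bound to a carbonyl carbon, gives a 4.0-fold higher number from compound 2 to compound 3 (0.60 log units; beyond the scatter), so this position is sensitive to the change and more compound is needed once the new group is present. The two groups have the same counts of heavy atoms, hydrogen-bond donors and acceptors and the same net charge, so the step does not follow any of these counts; they differ in their rings, double bonds and defined stereocentres. Nothing measured here accounts for the step.

As far as these compounds go, this is a single pair, so whether the step holds with the same exchange on a different remainder of the molecule stays open. Also open, from the compounds shown here alone, is how this assay would read with an amine or a carboxylic acid on that saturated chain carbon, in place of either ring-bearing group.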